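The compounds below may be only part of what the source reports. "The series", "measured", "known", "first", "only" and "open" are said of these compounds alone.

Of the compounds shown here, three sharing one core have been measured in an assay on CHO cells for antagonist activity at transient receptor potential cation channel subfamily V member 1 (Homo sapiens), read by FLIPR; a higher number here means a weaker inhibitor, a lower number a stronger inhibitor. Compound 1 `CCC1CCN(c2cc(C(F)(F)F)ccc2CNC(=O)C(C)c2ccc(NS(C)(=O)=O)c(F)c2)CC1` gives 0.7 nM in this assay. Compound 2 `CCCOc1cc(C(F)(F)F)ccc1CNC(=O)C(C)c1ccc(NS(C)(=O)=O)c(F)c1` gives 2 nM. Compound 3 `CC(C)CCOc1cc(C(F)(F)F)ccc1CNC(=O)C(C)c1ccc(NS(C)(=O)=O)c(F)c1` gives 0.5 nM. Compound 3 has the lowest of the three numbers; its separation from compound 1 is small, a 1.4-fold lower number from compound 1 to compound 3 (0.15 log units; within the scatter), while the separation from compound 2 is larger, a 4.0-fold lower number from compound 2 to compound 3 (0.60 log units; beyond the scatter). The remaining pair is split by the step of a 2.9-fold higher number from compound 1 to compound 2 (0.46 log units; beyond the scatter).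

Compound 4 `CCCCSc1cc(C(F)(F)F)ccc1CNC(=O)C(C)c1ccc(NS(C)(=O)=O)c(F)c1` has not yet been measured. It differs from compound 3 in one place: butylsulfanyl in place of isopentyloxy on an aromatic carbon. Two of the measured steps bear on this. The step of a 4.0-fold lower number from compound 2 to compound 3 (0.60 log units; beyond the scatter) shows that lengthening the chain attached to the oxygen gave a lower number; compound 4 carries a chain shorter than that of compound 3 but longer than that of compound 2, so part of that gain may be lost. For the measured compounds named here, no measured pair shows what replacing the oxygen by sulfur does, so that part of the change is open. The expected step is therefore a modest rise, a 2.0-fold higher number from compound 3 to compound 4 (0.30 log units; within the scatter). Compound 4 is estimated to give 1 nM in this assay, with a range from 0.3 nM to 3.5 nM.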

Compound 4, inhibition constant: 1.9 nM
Beside the measured number, compound 4's estimate is 1.9-fold (0.28 log units) below it, and the stated range covers the measured number.
By their numbers in this assay, from the lowest: compounds 3 and 1 (each within the scatter of the next); then compounds 4 and 2 (each within the scatter of the next).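

In this assay, butylsulfanyl on this aromatic carbon falls short of isopentyloxy, a change read as a 3.8-fold higher number from compound 3 to compound 4 (0.58 log units; beyond the scatter) in this series, and it also falls short of 4-ethylpiperidin-1-yl, as a 2.7-fold higher number from compound 1 to compound 4 (0.43 log units; beyond the scatter) shows. Set against propoxy, the same group gives a 1.1-fold lower number from compound 2 to compound 4 (0.02 log units; within the scatter) and so cannot be told apart from it, which means that a chain with sulfur as its link does not reach the level of the isopentyloxy chain. This single change alters the linking atom and the chain together, so the compounds cannot show how much of the step belongs to each, and no measurement offered here explains the differences among these groups.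

A butoxy group at this carbon would separate the two parts, since it keeps the butyl chain of compound 4 but links it through oxygen, while an isopentylsulfanyl group would test sulfur on the chain of compound 3. A longer chain, such as hexyloxy, would show whether the numbers continue to fall as the oxygen-linked chain grows beyond isopentyloxy.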